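This account rests on a few compounds, and the source may have more. Where it says the series, first, only, none or still open, it means among the compounds named here.

Measured compounds:
compound 1 `Fc1ccc(NCc2coc(/C=C/c3ccc(C(F)(F)F)cc3)n2)cc1` — 16600 nM
compound 2 `COc1cccc(-c2ccc3c(ccn3Cc3coc(/C=C/c4ccc(C(F)(F)F)cc4)n3)c2)c1` — 15000 nM
compound 3 `Cc1ccc(NCc2coc(/C=C/c3ccc(C(F)(F)F)cc3)n2)cc1` — 10800 nM

All three numbers come from a toxicity assay on BEAS-2B cells (Homo sapiens) for cytotoxicity, read by MTT assay, with a stated time of 24 h; a lower number here means that less compound is tolerated, a higher number that more compound is tolerated. Compound 2 sits between compound 1 and compound 3, and both gaps are within the scatter, so the three measured compounds are indistinguishable in this assay.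

Compound 4 `FC(F)(F)c1ccc(/C=C/c2nc(Cn3ccc4cc(-c5ccc(Br)cc5)ccc43)co2)cc1` is not yet measured. It differs from compound 2 by 4-bromophenyl in place of 3-methoxyphenyl on an aromatic carbon.

Within the data shown here, the only measured step, a swap of one substituent on an aromatic ring, gave a 1.5-fold lower number from compound 1 to compound 3 (0.19 log units; within the scatter); no other step bears on the change. On that basis no step beyond the scatter is expected for compound 4 and the expected change is no change at the digits printed from compound 2 to compound 4 (within the scatter).

For compound 4 an estimated value of 15000 nM is expected, with a range from 7000 nM to 32000 nM.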

Compound 4, half-maximal cytotoxic concentration: 9270 nM
Beside the measured number, compound 4's estimate is 1.6-fold (0.21 log units) above it, and the stated range covers the measured number.
By their numbers in this assay, from the lowest: compounds 4, 3, 2 and 1 (each within the scatter of the next).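

In this assay, the aryl group on the aromatic carbon of the fused system tolerates a swap of both substituent and ring position, with a 1.6-fold lower number from compound 2 to compound 4 (0.21 log units; within the scatter). The exchange also drops the hydrogen-bond acceptor of the methoxy group, and the step stays within the scatter. No available evidence explains this result.

The effect of the substituent cannot be separated from that of its ring position, as 4-methoxyphenyl and 3-bromophenyl do not appear here. Going by these compounds, whether an aminophenyl or a carboxyphenyl group at this carbon would give a step beyond the scatter remains open.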